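The compounds below may be only part of what the source reports. "The series", "measured", "known", "first", "only" and "open" are said of these compounds alone.

Measured so far in an ADME assay on microsomes (Homo sapiens) for metabolic stability; on this read-out higher numbers stand for fast clearance and lower numbers for slow clearance:
compound 1 `CNC(=O)[C@@H]1CCCN1S(=O)(=O)c1ccc(Cl)c(COc2cccc3c(-c4nccn4C)cc(C)nc23)c1Cl` gives 117 mL/min/kg
compound 2 `CNC(=O)[C@@H]1CCCN1S(=O)(=O)c1ccc(Cl)c(COc2cccc3c(OCc4ccccc4)cc(C)nc23)c1Cl` gives 467 mL/min/kg
compound 3 `CNC(=O)[C@@H]1CCCN1S(=O)(=O)c1ccc(Cl)c(COc2cccc3c(-c4ccccn4)cc(C)nc23)c1Cl` gives 183 mL/min/kg

Compound 3 stands close to one relative and apart from the other, as the two gaps show: a 1.6-fold higher number from compound 1 to compound 3 (0.19 log units; within the scatter) and a 2.6-fold lower number from compound 2 to compound 3 (0.41 log units; beyond the scatter). Compound 4 `CNC(=O)[C@@H]1CCCN1S(=O)(=O)c1ccc(Cl)c(COc2cccc3c(-c4cccnc4)cc(C)nc23)c1Cl` has the same atoms joined differently: pyridin-3-yl in place of pyridin-2-yl on an aromatic carbon with pyridin-3-yl in place of pyridin-2-yl on an aromatic carbon. Among the compounds with values here, the nearest precedent, one aromatic ring exchanged for another, is the small 1.6-fold higher number from compound 1 to compound 3 (0.19 log units; within the scatter) and the larger 2.6-fold lower number from compound 2 to compound 3 (0.41 log units; beyond the scatter) involves benzyloxy, which plays no part here. Within the data shown here, no measured pair compares two pyridine attachments directly, so no step beyond the scatter is expected in this assay. The expected change is a 1.0-fold lower number from compound 3 to compound 4 (0.01 log units; within the scatter). For compound 4 the estimated clearance is 180 mL/min/kg with an expected range from 95 mL/min/kg to 340 mL/min/kg.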

Compound 4, clearance: 233 mL/min/kg
The estimate for compound 4 lay 1.3-fold (0.11 log units) below the measured number; the measured number falls inside the stated range.
By their numbers in this assay, from the lowest: compounds 1, 3, 4 and 2 (each within the scatter of the next, the first and the last beyond it).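

In this assay the shift from pyridin-2-yl to pyridin-3-yl gives a 1.3-fold higher number from compound 3 to compound 4 (0.10 log units; within the scatter) and so, at this position opposite the ring nitrogen, the two pyridine attachments cannot be told apart. Compound 4 also stays within the scatter of both other relatives, with a 2.0-fold higher number from compound 1 to compound 4 (0.30 log units; within the scatter) and a 2.0-fold lower number from compound 2 to compound 4 (0.30 log units; within the scatter) even though those two relatives lie beyond the scatter of each other. No measurement offered here explains these numbers. Still open, as far as these compounds go, is whether a pyridin-4-yl ring, or a pyridine carrying an amine or a carboxylic acid, would give a clear step at this position.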